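A few compounds are considered here, and "the series" means these few. Any claim that something is new, unique, unknown or untested is made for them only; others in the source may bear on it.

Measured so far in a functional assay on CHO-K1 cells (Cricetulus griseus) for inhibition, read by MTT assay, with a stated time of 72 h; a higher number here means a weaker inhibitor, a lower number a stronger inhibitor:
- compound 1 `C=CCNC(=C\C(=O)/C=C/c1ccc(O)c(OC)c1)/C=C/c1ccc(O)c(OC)c1` gives 7400 nM
- compound 2 `COc1cc(/C=C/C(=O)/C=C(/C=C/c2ccc(OC(C)=O)c(OC)c2)NC2CCCCC2)ccc1OC(C)=O` gives 10100 nM
- compound 3 `COc1cc(/C=C/C(=O)/C=C(/C=C/c2ccc(OC(C)=O)c(OC)c2)NCC(C)C)ccc1OC(C)=O` gives > 25000 nM, a limit of the assay and not a number

Compound 1 holds the lowest of the two numbers shown, but compound 2 sits within the scatter of it, so no order between the two can be read. Compound 3 is known only as a limit (the limit of > 25000 nM in this assay, at which 1 of the 3 values shown sits).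

Compound 4 `CCCCNC(=C\C(=O)/C=C/c1ccc(O)c(OC)c1)/C=C/c1ccc(O)c(OC)c1` is not yet measured. It differs from compound 1 by propyl in place of vinyl on a saturated chain carbon bound to an amine nitrogen, that is, allyl to butyl, allylamino to butylamino.

For the measured compounds named here, the only measured change on the amine nitrogen is an at least 2.4-fold higher number from compound 2 to compound 3 (0.39 log units; beyond the scatter), a move from a ring to a branched chain against a backdrop of acetylated phenols rather than the free phenols of compound 1 and compound 4. It shows that the amine substituent can shift the number, but it is not the same change, and the saturation of a short straight chain is a smaller alteration. The expectation for compound 4 in this assay is therefore a step of a 1.2-fold higher number from compound 1 to compound 4 (0.09 log units; within the scatter), that is, no move beyond the scatter and, if anything, a slightly higher number.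

Compound 4 is estimated at 9000 nM, with a range from 4000 nM to 20000 nM.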

Compound 4, half-maximal inhibitory concentration: 7000 nM
Estimate against measurement, compound 4: 1.3-fold (0.11 log units) above, and the stated range covers the measured number.
By their numbers in this assay, from the lowest: compounds 4, 1 and 2 (each within the scatter of the next). At a limit, above all of these: compound 3.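

In this assay, for the compounds shown here, the step of a 1.1-fold lower number from compound 1 to compound 4 (0.02 log units; within the scatter) is the first one read on the amine nitrogen with the free phenols in place, and it lies within the scatter, so exchanging allyl for butyl, which removes the double bond from the chain, leaves no readable mark on the number. Going by these compounds alone, the earlier step of an at least 2.4-fold higher number from compound 2 to compound 3 (0.39 log units; beyond the scatter) showed only that a change at this nitrogen can shift the number on the acetylated phenols, whereas this pair shows that a change at the same nitrogen can also leave the number in place, at least for these two straight chains. Nothing among the data shown gives a reason for the absence of a readable step.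

Open, going by these compounds, is whether a longer chain such as octyl, a benzyl group or a hydroxyethyl group on the amine nitrogen would hold the number of the free phenols, and whether cyclohexyl and isobutyl would separate there as they do on the acetylated phenols. The value of compound 3 remains a limit of the assay and not a number.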